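A few compounds are considered here, and "the series" means these few. Any claim that something is new, unique, unknown or untested is made for them only; others in the source may bear on it.

In a functional assay (aorta) for inhibition, with Rattus norvegicus as the target (on this read-out higher numbers stand for weaker inhibition and lower numbers for stronger inhibition), compound 1 `CC(C)/N=C(\S)[C@]1(c2cccnc2)CCCC[S+]1[O-]` gives 10000 nM and compound 2 `CCCC/N=C(\S)[C@]1(c2cccnc2)CCCC[S+]1[O-]` gives 8000 nM, so the two cannot be told apart. Within the data shown here, the only measured step, a 1.3-fold lower number from compound 1 to compound 2 (0.10 log units; within the scatter), swaps isopropyl for butyl on the double-bonded nitrogen. Compound 3 `[O-][S+]1CCCC[C@]1(CO)c1cccnc1` differs from compound 1 far more widely: a group of 2 heavy atoms (1 carbon, 1 oxygen; no ring) in place of a group of 6 heavy atoms (4 carbon, 1 nitrogen, 1 sulfur; no ring), on a saturated ring carbon. Here hydroxymethyl replaces the whole group bearing that nitrogen, on a saturated ring carbon of the shared core. Among the measured compounds shown here, the measured step leaves that group in place, so it says little about its removal, showing only that one change on the nitrogen stayed within the scatter. With so little evidence, a moderate move towards weaker inhibition in this assay is expected, though with wide uncertainty. The expected change is a 2.0-fold higher number from compound 1 to compound 3 (0.30 log units; within the scatter). For compound 3 the estimated value is 20000 nM, with an expected range of 6000 nM to 80000 nM.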

Compound 3, concentration for 90% inhibition: > 30000 nM
Compound 3: only a limit was reported; the forecaster's own chance of this, stated with the estimate: 40%; middle value at least 1.5-fold (0.17 log units) from the limit.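

Replacing the whole group bearing the double-bonded nitrogen with hydroxymethyl, on a saturated ring carbon of the shared core, gives an at least 3.0-fold higher number from compound 1 to compound 3 (0.47 log units; beyond the scatter) in this assay. Among these compounds, the earlier step, a 1.3-fold lower number from compound 1 to compound 2 (0.10 log units; within the scatter), changed only the group on that nitrogen, so this is the first sign that a change at this ring carbon can move the read-out beyond the scatter. Going by these compounds, compound 3 is known only as a limit, so the full size of the step stays open: the limit of > 30000 nM in this assay, at which 1 of the 3 values shown sits.

The compounds shown do not separate the parts of the departing group, so the sulfur, the double-bonded nitrogen and the group on that nitrogen remain unresolved. On these data alone, how a carboxylic acid or an aminomethyl group on this ring carbon would read in this assay also remains open.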